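The source may report more compounds than this note shows. Statements on the series, on what has been measured and on what is new or still open speak of the compounds shown alone.

Three measured members of the series share one core and differ in the aryl group on a saturated chain carbon bound to an amine nitrogen. Compound 1 `O=S(=O)(NCCCNCc1cccc2ccccc12)c1cc(C(F)(F)F)cc(C(F)(F)F)c1` gives 2600 nM in a functional assay on HT-29 cells (Homo sapiens) for inhibition, read by MTT assay, with a stated time of 72 h; a higher number here means a weaker inhibitor of growth, a lower number a stronger inhibitor of growth. Compound 2 `O=S(=O)(NCCCNCc1ccc(Cl)cc1)c1cc(C(F)(F)F)cc(C(F)(F)F)c1` gives 2800 nM in this assay, and compound 3 `O=S(=O)(NCCNCc1ccc(-c2ccccc2)cc1)c1cc(C(F)(F)F)cc(C(F)(F)F)c1` gives 2700 nM. Compound 2 has the highest of the three numbers, yet its gaps to compound 3 and to compound 1 are both within the scatter, so no order among the three can be read. Going by the values given here, the single one-point step measured so far, a 1.1-fold higher number from compound 1 to compound 2 (0.03 log units; within the scatter), is within the scatter.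

Compound 4 `COc1cccc(CNCCCNS(=O)(=O)c2cc(C(F)(F)F)cc(C(F)(F)F)c2)c1` is not yet measured. It differs from compound 2 as follows: 3-methoxyphenyl in place of 4-chlorophenyl on a saturated chain carbon bound to an amine nitrogen. Among the compounds with values here, the only step bearing on such an exchange of one aryl group for another on a saturated chain carbon bound to an amine nitrogen is a 1.1-fold higher number from compound 1 to compound 2 (0.03 log units; within the scatter), and it was within the scatter; compound 3 sits in the same range as well. The expectation is therefore no step beyond the scatter, a 1.0-fold lower number from compound 2 to compound 4 (0.02 log units; within the scatter). Compound 4 is estimated at 2700 nM in this assay, with a range from 1300 nM to 5500 nM.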

Compound 4, concentration for 50% growth inhibition: 10000 nM
Compound 4: middle estimate off by 3.7-fold (0.57 log units), on the low side, outside the stated range (above it).
By their numbers in this assay, from the lowest: compounds 1, 3 and 2 (each within the scatter of the next); then compound 4.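

The aryl position on the saturated chain carbon bound to an amine nitrogen is not indifferent to the group it carries. In this assay, going by these compounds alone, 3-methoxyphenyl in place of 4-chlorophenyl gives the first step in this set beyond the scatter (a 3.6-fold higher number from compound 2 to compound 4 (0.55 log units; beyond the scatter)), and 3-methoxyphenyl in place of naphthalen-1-yl points the same way (a 3.8-fold higher number from compound 1 to compound 4 (0.59 log units; beyond the scatter)), towards weaker growth inhibition. The flat reading across compound 1 and compound 2 therefore holds for naphthalen-1-yl and 4-chlorophenyl but does not extend to every aryl group.

As far as these compounds go, whether the shift follows the methoxy group itself or its place on the ring stays open, as does how an aryl group carrying an amine or a carboxylic acid would read here. No measurement shown bears on the reason for this step.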